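Swapping cyclohexyl for 4-fluorophenyl on a carbonyl carbon

The source may hold more compounds than are shown below. What is called first, only, known or untested is meant among the compounds shown, and "the series" means these compounds.

- Compound 1 `O=C(OC1CCC(CN2CCN(c3cc(=O)c4cc(C(F)(F)F)cc([N+](=O)[O-])c4s3)CC2)CC1)c1ccccc1` gives 0.903 h 
- Compound 2 `O=C(OC1CCC(CN2CCN(c3cc(=O)c4cc(C(F)(F)F)cc([N+](=O)[O-])c4s3)CC2)CC1)C1CCCCC1` gives 0.0783 h 

In an ADME assay on cells (Hepatocyte, Mus musculus) for metabolic stability (a higher number here means that the compound lasts longer, a lower number that the compound disappears faster), compound 2 stands lowest of the two measured compounds, at 0.0783 h on the half-life scale, so it disappears faster than compound 1. Compound 3 `O=C(OC1CCC(CN2CCN(c3cc(=O)c4cc(C(F)(F)F)cc([N+](=O)[O-])c4s3)CC2)CC1)c1ccc(F)cc1`, not yet measured, carries 4-fluorophenyl in place of cyclohexyl on a carbonyl carbon. Going by the values given here, one measured step bears on this change. The step of a 12-fold lower number from compound 1 to compound 2 (1.06 log units; beyond the scatter) came with cyclohexyl in place of phenyl on a carbonyl carbon, and it is large. Among the compounds with values here, no measured pair shows what the fluorine alone does. Run backwards, that step points to an expected large rise in this assay, estimated as a 10-fold higher number from compound 2 to compound 3 (1.01 log units; beyond the scatter) in size. For compound 3 the estimated half-life is 0.8 h (expected range 0.3 h to 2 h).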

Compound 3, half-life: 0.0817 h
Beside the measured number, compound 3's estimate is 9.8-fold (0.99 log units) above it; the measured number lies below the stated range.
By their numbers in this assay, from the lowest: compounds 2 and 3 (each within the scatter of the next); then compound 1.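

In this assay the swap of cyclohexyl for 4-fluorophenyl on a carbonyl carbon gives a 1.0-fold higher number from compound 2 to compound 3 (0.02 log units; within the scatter) and leaves the two compounds level, so an aromatic ring at this position does not by itself go with the longer half-life. Fluoro in place of hydrogen on an aromatic carbon gives an 11-fold lower number from compound 1 to compound 3 (1.04 log units; beyond the scatter) and sets compound 3 well apart from compound 1, so in this pair one added fluorine comes with a large difference. Nothing available explains why these two results fall as they do.

Going by these compounds, whether a chloro or a methoxy group on that same aromatic carbon would go with a number like that of compound 1 or like that of compound 3 remains open. Also open, on these data alone, is whether fluoro on a different aromatic carbon of the ring would give the same large step.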